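The source may report more compounds than this note shows. Statements on the series, on what has been measured and on what is new or still open speak of the compounds shown alone.

Compound 1 `CCCNc1nc(C)c(-c2nc3ccccc3s2)c(N[C@@H]2C[C@H](CO)[C@@H](O)[C@H]2O)n1` — > 25000 nM
Compound 2 `Cc1nc(N(C)C)nc(N[C@@H]2C[C@H](CO)[C@@H](O)[C@H]2O)c1-c1nc2ccccc2s1` — 18000 nM
Compound 3 `CCc1nc(N(C)C)nc(N[C@@H]2C[C@H](CO)[C@@H](O)[C@H]2O)c1-c1nc2ccccc2s1` — > 25000 nM

Among the measured compounds shown here, in an ADME assay on cells (Homo sapiens) for cytotoxicity, read by polymerase chain reaction, with a stated time of 3 days (on this read-out lower numbers stand for higher toxicity in this test and higher numbers for lower toxicity in this test), compound 2 gives 18000 nM, and this is the only number among the three compounds. Compound 1 gives a limit of the assay at > 25000 nM. Compound 3 also gives a limit of the assay at > 25000 nM. For the measured compounds named here, two of the three values thus sit at the limit of > 25000 nM in this assay, at which 2 of the 3 values shown sit, so compound 2 stands as the single compound with a measured number, and its distance from the other two is not known beyond the floors of the steps.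

Those floors are small: an at least 1.3-fold lower number from compound 1 to compound 2 (0.14 log units; that floor lies within the scatter), with dimethylamino in place of propylamino on an aromatic carbon; and an at least 1.3-fold higher number from compound 2 to compound 3 (0.14 log units; that floor lies within the scatter), with methyl in place of hydrogen on a saturated chain carbon bound to an aromatic carbon.

Compound 4 `Cc1nc(Nc2ccccc2)nc(N[C@@H]2C[C@H](CO)[C@@H](O)[C@H]2O)c1-c1nc2ccccc2s1` differs from compound 2 by anilino in place of dimethylamino on an aromatic carbon. The step from compound 1 to compound 2 bears on this change, since it also exchanged the group on that same aromatic carbon, and its floor lay within the scatter. No step beyond the scatter is therefore expected in this assay: a 1.2-fold higher number from compound 2 to compound 4 (0.09 log units; within the scatter). Compound 4 is estimated at 22000 nM, between 9000 nM and 50000 nM, with a fair chance that only a limit is reported.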

Compound 4, half-maximal cytotoxic concentration: > 25000 nM
Compound 4: only a limit was reported; the forecaster's own chance of this, stated with the estimate: 45%; at least 1.1-fold (0.05 log units) between middle value and limit.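

In this assay compound 4 gives > 25000 nM, a limit of the assay and not a number. Among the compounds shown here, with anilino on the aromatic carbon between two ring nitrogen atoms, the result is an at least 1.3-fold higher number from compound 2 to compound 4 (0.14 log units; that floor lies within the scatter), so a substituent carrying a six-membered aromatic ring of carbon only can stand at this place and the read-out still ends at a limit, which the smaller propylamino and dimethylamino groups of the earlier compounds could not show. The step between compound 1 and compound 4 cannot be read, and the set now gathers at a single limit: the limit of > 25000 nM in this assay, at which 3 of the 4 values shown sit.

As far as these compounds go, how far compound 1, compound 3 and compound 4 lie from that limit stays unknown, and with only compound 2 giving a number, it remains open whether the group at this carbon changes the read-out beyond the scatter at all. Also open, from the compounds shown here alone, is how a longer alkyl chain on the nitrogen, a benzylamino group or a morpholine at this same carbon would read in this assay.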